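Working notes: phenoxy to methoxy on compound 3

A few compounds are considered here, and "the series" means these few. Any claim that something is new, unique, unknown or untested is made for them only; others in the source may bear on it.

Measured in a functional assay on M21 cells (Homo sapiens) for antiproliferative activity, read by sulforhodamine B assay, with a stated time of 48 h; on this read-out lower numbers stand for stronger inhibition and higher numbers for weaker inhibition:
- compound 1 `CCc1ccc(NS(=O)(=O)c2ccc(N3CCNC3=O)cc2)cc1`: 480 nM
- compound 2 `O=C1NCCN1c1ccc(S(=O)(=O)Nc2ccc(Br)cc2)cc1`: 130 nM
- compound 3 `O=C1NCCN1c1ccc(S(=O)(=O)Nc2cccc(Oc3ccccc3)c2)cc1`: 83 nM

Compound 3 gives 83 nM and compound 2 gives 130 nM, two values within the scatter of each other. Compound 1 gives 480 nM, a higher number than either, beyond the scatter.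

Compound 4 `COc1cccc(NS(=O)(=O)c2ccc(N3CCNC3=O)cc2)c1` is the next point, with methyl in place of phenyl on an oxygen on an aromatic ring, so phenoxy becomes methoxy: methyl in place of phenyl on an oxygen on an aromatic ring.

For the measured compounds named here, no measured step covers this exchange. Going by the values given here, the only single-place step is a 3.7-fold lower number from compound 1 to compound 2 (0.57 log units; beyond the scatter), bromo in place of ethyl on an aromatic carbon, which is a different exchange and modest in size. It serves only as a guide to size, and the direction remains a judgement. A modest rise in this assay is expected. The estimated change is a 3.6-fold higher number from compound 3 to compound 4 (0.56 log units; beyond the scatter). For compound 4 the expected value is 300 nM, with an estimated range of 110 nM to 800 nM.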

Compound 4, half-maximal inhibitory concentration: 65 nM
The estimate for compound 4 lay 4.6-fold (0.66 log units) above the measured number; the measured number lies below the stated range.
By their numbers in this assay, from the lowest: compounds 4, 3 and 2 (each within the scatter of the next); then compound 1.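

In this assay, replacing the phenyl on this oxygen with methyl gives a 1.3-fold lower number from compound 3 to compound 4 (0.11 log units; within the scatter) and so no readable difference: the outer aromatic ring of the phenoxy group is not required for the activity of compound 3, and a single carbon on the oxygen serves as well. For the compounds shown here, on the sulfonamide nitrogen, the 3-methoxyphenyl and 4-bromophenyl groups are not separated, with a 2.0-fold lower number from compound 2 to compound 4 (0.30 log units; within the scatter) and the 3-methoxyphenyl group is clearly distinguished only from 4-ethylphenyl, with a 7.4-fold lower number from compound 1 to compound 4 (0.87 log units; beyond the scatter) as the one step here beyond the scatter. Nothing available bears on the reason for these results.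

The compounds shown leave open whether the oxygen itself matters at this place, since no group without it, such as an amine or a plain ethyl chain, stands in its stead. They also leave open how a longer chain on the oxygen, such as propyl or benzyl, would read in this assay here.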